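This account rests on a few compounds, and the source may have more. Where it says the series, first, only, none or still open, it means among the compounds named here.

In an ADME assay on HEK293 cells (Homo sapiens) for cytotoxicity, read by MTT assay, with a stated time of 48 h (a lower number here means a stronger inhibitor, a higher number a weaker inhibitor), compound 1, `CCS(=O)(=O)Nc1ccc(NC(=O)c2ccc(Cl)c([N+](=O)[O-])c2)cc1C`, gives 144000 nM. Compound 2, `Cc1cc(NC(=O)c2ccc(Cl)c([N+](=O)[O-])c2)ccc1NS(=O)(=O)C(F)(F)F`, differs from it by trifluoromethyl in place of ethyl on a sulfonyl sulfur. For compound 2 this assay reports only a limit, > 250000 nM. The step that this change made is an at least 1.7-fold higher number from compound 1 to compound 2 (0.23 log units; that floor lies within the scatter). Compound 3, `CCS(=O)(=O)Nc1ccc(NC(=O)c2ccc(Cl)cc2)cc1Cl`, rests on a different core; how its core differs from that of compound 1 is not broken down here. For compound 3 this assay likewise reports only a limit, > 250000 nM. Compound 4, `O=C(Nc1ccc(NS(=O)(=O)C(F)(F)F)c(Cl)c1)c1ccc(Cl)cc1`, is not yet measured in this assay; it differs from compound 3 by trifluoromethyl in place of ethyl on a sulfonyl sulfur, the same change as that from compound 1 to compound 2, at the same place. What the measured compounds offer is the limit of > 250000 nM in this assay, at which 2 of the 3 values shown sit, and compound 3 already stands there. The step expected from compound 3 to compound 4 in this assay is a step that the limit leaves unreadable from compound 3 to compound 4, resting on the limit that compound 3 shows with > 250000 nM. Compound 4 is therefore expected to give about 320000 nM, between 150000 nM and 700000 nM, most probably reported as a limit rather than a number.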

Compound 4, half-maximal inhibitory concentration: 191000 nM
The estimate for compound 4 lay 1.7-fold (0.22 log units) above the measured number; the range from low to high includes it.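

With compound 4 measured, the change from ethyl to trifluoromethyl on a sulfonyl sulfur can be followed on a second core in this assay, and it reads as an at least 1.3-fold lower number from compound 3 to compound 4 (0.11 log units; that floor lies within the scatter). This does not show that the change carries from one core to another with the same outcome, nor that it carries differently, since the two steps point in opposite directions only as floors and neither is shown to lie beyond the scatter: the same change on two cores in this assay, an at least 1.7-fold higher number (0.23 log units; that floor lies within the scatter) from compound 1 to compound 2 and an at least 1.3-fold lower number (0.11 log units; that floor lies within the scatter) from compound 3 to compound 4; the limit leaves it open whether they differ Any reading of the pair is further bounded by how many of the values are limits and not numbers: the limit of > 250000 nM in this assay, at which 2 of the 4 values shown sit.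

The compounds shown leave open how the change would behave on a core where both partners give a number, and which part of the difference between the core of compound 1 and the core of compound 3 matters. They also leave open whether a longer chain or an amine on the sulfonyl sulfur would fall in line with ethyl or with trifluoromethyl.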